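The source may report more compounds than this note shows. Statements on the series, on what has been measured and on what is new or still open speak of the compounds shown alone.

Measured compounds:

Compound 1, `CCCn1cnc2c(N(C)C)ncnc21`: in a functional assay on the whole organism for antagonist activity, with Rattus norvegicus as the target (on this read-out higher numbers stand for an effect only at larger amounts of compound and lower numbers for an effect already at smaller amounts), compound 1 gives 14 mg/kg.
Compound 2, `CCC(C)n1cnc2c(N(C)C)ncnc21`: in this assay compound 2 gives 14 mg/kg.
Compound 3, `CNc1nc(NC2CC2)c2ncn(CC3CC3)c2n1`: in this assay compound 3 gives 3 mg/kg.

Compound 1 and compound 2 share one core, and compound 3 is built on a different one; how the two cores differ is not broken down here. Compound 2 is made from compound 1 by a single change, (methyl in place of hydrogen on a saturated chain carbon bound to an aromatic nitrogen and a saturated chain carbon), and that change made no change at the digits printed from compound 1 to compound 2 (within the scatter). Compound 3 stands apart from both of the others, with a dose lower than that of compound 1 and that of compound 2 by a gap beyond the usual scatter.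

Compound 4, `CCNc1nc(NC2CC2)c2ncn(CC3CC3)c2n1`, has not yet been measured. It is made from compound 3 by the change (methyl in place of hydrogen on a saturated chain carbon bound to a nitrogen on an aromatic ring). For the measured compounds named here, this is the same kind of change as the one from compound 1 to compound 2, though not the same: in the first case the carbon that gains the methyl is bound to an aromatic nitrogen and a saturated chain carbon, in the second it is bound to a nitrogen on an aromatic ring. Since the earlier step made no change at the digits printed from compound 1 to compound 2 (within the scatter), a similarly small step is expected here, and in this assay the expected step from compound 3 to compound 4 is no change at the digits printed from compound 3 to compound 4 (within the scatter). On that basis, compound 4 is estimated to give 3 mg/kg in this assay, most likely between 1.5 mg/kg and 7 mg/kg.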

Compound 4, dose for half-maximal effect: 9 mg/kg
Estimate against measurement, compound 4: 3.0-fold (0.48 log units) below, and the stated range ends below it.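

In this assay, a methyl in place of hydrogen on a saturated chain carbon bound to a nitrogen on an aromatic ring, which turns methylamino into ethylamino, gave a 3.0-fold higher number from compound 3 to compound 4 (0.48 log units; beyond the scatter), so compound 4 needs a larger dose than compound 3 for the same effect. On the core of compound 1, the closely related methyl addition gave no change at the digits printed from compound 1 to compound 2 (within the scatter), and so in this small set a methyl that made no visible difference on one core cannot be assumed to do the same on another: the same change on two cores in this assay, no change at the digits printed (within the scatter) from compound 1 to compound 2 and a 3.0-fold higher number (0.48 log units; beyond the scatter) from compound 3 to compound 4, 3.0-fold (0.48 log units) apart, beyond the scatter of two such steps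

This comparison rests on a single pair for each core, and the carbon that gains the methyl is bound differently in the two pairs, so it does not show whether the core, the place of the methyl or something else accounts for the gap, nor does it give a general rule for the series.

The compounds shown leave open what a butyl chain, or a chain carrying a hydroxyl group, would do in place of the ethyl of compound 4. They also leave open whether a methylamino to ethylamino step would give a similar result on other cores.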